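Dropping One Methoxy Group from Compound 1

This account rests on a few compounds, and the source may have more. Where it says the series, first, only, none or still open, it means among the compounds named here.

For the measured compounds named here, compound 1 `COc1cc(-c2cc(/C=C/C(=O)c3ccc(N)cc3)[nH]n2)cc(OC)c1OC` is the only compound here with a numbered result: in a functional assay on COLO 205 cells (Homo sapiens) for inhibition, read by sulforhodamine B assay, with a stated time of 48 h (on this read-out lower numbers stand for higher toxicity in this test and higher numbers for lower toxicity in this test), compound 1 gives 6420 nM. Compound 2 `COc1cc(-c2cc(/C=C/C(=O)c3ccc(Cl)c(Cl)c3)[nH]n2)cc(OC)c1OC` reaches only a limit of the assay, giving > 100000 nM in this assay. Going by the values given here, the one measured step, an at least 15-fold higher number from compound 1 to compound 2 (1.19 log units; beyond the scatter), changes the group on the carbonyl carbon and so says nothing about the methoxy groups. Compound 3 `COc1ccc(-c2cc(/C=C/C(=O)c3ccc(N)cc3)[nH]n2)cc1OC` differs from compound 1 in exactly that region: hydrogen in place of methoxy on an aromatic carbon. Among the compounds with values here, with no measured step bearing on this change, a shift within the usual scatter is expected, a 1.6-fold higher number from compound 1 to compound 3 (0.19 log units; within the scatter). Compound 3 is therefore estimated at 10000 nM, between 3000 nM and 40000 nM.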

Compound 3, concentration lethal to 50% of the cells: 6870 nM
Beside the measured number, compound 3's estimate is 1.5-fold (0.16 log units) above it; the range from low to high includes it.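

In this assay the change gives a 1.1-fold higher number from compound 1 to compound 3 (0.03 log units; within the scatter), so replacing this methoxy with hydrogen leaves the number effectively unchanged. For the compounds shown here, the earlier compounds varied only the group on the carbonyl carbon, so this is the first reading at this position on the other aromatic ring. Nothing available here explains why this methoxy can be lost without a measurable shift.

Still open, going by these compounds, is whether the two remaining methoxy groups can also be removed. It is equally unclear whether a hydroxyl, a fluorine or an ethoxy at this position would shift the number.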